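The source may hold more compounds than are shown below. What is called first, only, known or untested is meant among the compounds shown, and "the series" means these compounds.

Measured so far:
compound 1, `COc1cc(/C=C/C(=O)C2=C(/C=C/c3ccc(O)c(OC)c3)NC(=O)NC2c2ccccc2)ccc1O`, 38.2% in a functional assay, with a stated time of 20 min, tested at 20 uM; a lower number here means a weaker effect, a higher number a stronger effect of the compound at the concentration tested
compound 2, `COc1cc(/C=C/C(=O)C2=C(/C=C/c3ccc(O)c(OC)c3)NC(=O)NC2c2ccc(N(C)C)cc2)ccc1O`, 48% in this assay

Of these two numbers, compound 2 stands higher, though the step of a number 9.8 percentage points higher from compound 1 to compound 2 (within the scatter) lies within the scatter, so the two compounds cannot be told apart. Compound 3, `COc1cc(/C=C/C(=O)C2=C(/C=C/c3ccc(O)c(OC)c3)NC(=O)NC2c2c(Cl)cccc2Cl)ccc1O`, carries the change (2,6-dichlorophenyl in place of 4-(dimethylamino)phenyl on a saturated ring carbon). For the measured compounds named here, the only measured step, a number 9.8 percentage points higher from compound 1 to compound 2 (within the scatter), touched the same saturated ring carbon and was within the scatter; no step with a dichlorophenyl group exists. The step of a number 6 percentage points lower from compound 2 to compound 3 (within the scatter) is therefore expected to stay small, with no clear direction. Compound 3 is estimated at 42%, between 25% and 60%.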

Compound 3, a percentage reported as activity, at one concentration (the size of the read-out at that concentration, not a potency): 31.9%
For compound 3 the middle estimate is 10.1 percentage points above the measured one, and the stated range covers the measured number.
By their numbers in this assay, from the lowest: compounds 3, 1 and 2 (each within the scatter of the next, the first and the last beyond it).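

For the compounds shown here, at the saturated ring carbon, the choice of aromatic group can move the read-out in this assay by more than the scatter: 2,6-dichlorophenyl in place of 4-(dimethylamino)phenyl gives a number 16.1 percentage points lower from compound 2 to compound 3 (beyond the scatter) and is the first step at this position to do so. Set against plain phenyl, the same 2,6-dichlorophenyl group gives a number 6.3 percentage points lower from compound 1 to compound 3 (within the scatter) and so cannot be told apart from it. Nothing measured here accounts for either step.

From the compounds shown here alone, whether the dimethylamino group or the chlorines drive the difference remains open. So does the effect of a carboxylic acid or a methoxy group on this phenyl ring.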